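A Second Nitro Group on the Hydrazide Aryl Ring

This account rests on a few compounds, and the source may have more. Where it says the series, first, only, none or still open, it means among the compounds named here.

compound 1 `CCOC(=O)N1CCC(=NNC(=O)c2ccc([N+](=O)[O-])cc2)CC1`: > 400000 nM
compound 2 `CCOC(=O)N1CCC(=NNC(=O)c2ccc([N+](=O)[O-])cc2[N+](=O)[O-])CC1`: > 400000 nM
compound 3 `O=C(NN=C1CC(c2ccccc2)NC(c2ccccc2)C1)c1ccc([N+](=O)[O-])cc1`: > 400000 nM

All three were tested in a toxicity assay on BJ cells (Homo sapiens) for cytotoxicity, read by MTT assay, with a stated time of 24 h; a higher number here means a weaker inhibitor, a lower number a stronger inhibitor. For compound 1 the value > 400000 nM is a limit of the assay, not a number. For compound 2 the value > 400000 nM is likewise a limit. For compound 3 the value > 400000 nM is a limit as well. The change from compound 1 to compound 2 is nitro in place of hydrogen on an aromatic carbon, and it gave a step that the two limits leave unreadable from compound 1 to compound 2, both partners resting at the limit of > 400000 nM in this assay, at which 3 of the 3 values shown sit. The difference between the core of compound 1 and the core of compound 3 is not broken down here. Compound 4 `O=C(NN=C1CC(c2ccccc2)NC(c2ccccc2)C1)c1ccc([N+](=O)[O-])cc1[N+](=O)[O-]` carries the same change relative to compound 3, namely (nitro in place of hydrogen on an aromatic carbon). Because compound 3 sits at the limit of > 400000 nM in this assay, at which 3 of the 3 values shown sit, compound 4 is expected to show a step that the limit leaves unreadable from compound 3 to compound 4. Compound 4 is therefore estimated at 600000 nM.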

Compound 4, half-maximal inhibitory concentration: > 400000 nM
Compound 4 gave a limit, no number (the forecaster's own chance of this, stated with the estimate: 85%); the middle value is on the limit's open side.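

In this assay compound 4 gives > 400000 nM, a limit and not a number, so the step from compound 3 to compound 4 cannot be read: the limit of > 400000 nM in this assay, at which 4 of the 4 values shown sit. On these data alone, what nitro in place of hydrogen on an aromatic carbon does to the value in this assay stays open for both cores.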